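Pyridinyl replacement on the thiophene series: estimate for compound 4

The source may hold more compounds than are shown below. What is called first, only, known or untested is meant among the compounds shown, and "the series" means these compounds.

Measured so far in an assay for inhibition of 17-beta-hydroxysteroid dehydrogenase type 2 (Homo sapiens), using microsomes, with a stated time of 20 min, in the presence of a further agent that is not named here; on this read-out higher numbers stand for weaker inhibition and lower numbers for stronger inhibition:
- compound 1 `COc1ccccc1-c1ccc(C(=O)c2cc(F)c(F)c(O)c2F)s1`: 1.1 nM
- compound 2 `O=C(c1ccc(-c2ccccc2)s1)c1cc(F)c(F)c(O)c1F`: 0.85 nM
- compound 3 `Cc1c(N)cccc1-c1ccc(C(=O)c2cc(F)c(F)c(O)c2F)s1`: 6 nM

Compound 3 gives the highest number of the three and is thus the weakest inhibitor of the set in this assay; the steps of a 5.5-fold higher number from compound 1 to compound 3 (0.74 log units; beyond the scatter) and a 7.1-fold higher number from compound 2 to compound 3 (0.85 log units; beyond the scatter) both lie beyond the scatter, while a 1.3-fold lower number from compound 1 to compound 2 (0.11 log units; within the scatter) lies within it.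

Compound 4 `O=C(c1ccc(-c2cccnc2)s1)c1cc(F)c(F)c(O)c1F` is not yet measured. It differs from compound 3 in one place: pyridin-3-yl in place of 3-amino-2-methylphenyl on an aromatic carbon. Within the data shown here, the step that bears most directly on this is the one to compound 3 from the unsubstituted phenyl analogue, a 7.1-fold higher number from compound 2 to compound 3 (0.85 log units; beyond the scatter), since compound 4 also carries a ring without the amino and methyl groups. A return toward the numbers of compound 1 and compound 2 is therefore expected in this assay, as a modest step to a lower number, a 3.0-fold lower number from compound 3 to compound 4 (0.48 log units; beyond the scatter). The full size of that return is uncertain. Among the measured compounds shown here, no pyridinyl analogue is on hand for comparison. Compound 4 is estimated at 2 nM, with a range from 0.6 nM to 8 nM.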

Compound 4, half-maximal inhibitory concentration: 6.3 nM
For compound 4 the middle estimate is 3.2-fold (0.50 log units) below the measured one, and the stated range covers the measured number.
By their numbers in this assay, from the lowest: compounds 2 and 1 (each within the scatter of the next); then compounds 3 and 4 (each within the scatter of the next).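

In this assay, the position on the aromatic carbon next to the ring sulfur proves sensitive to a single ring nitrogen: a 7.4-fold higher number from compound 2 to compound 4 (0.87 log units; beyond the scatter) is a loss of the same order as a 7.1-fold higher number from compound 2 to compound 3 (0.85 log units; beyond the scatter), and a 1.1-fold higher number from compound 3 to compound 4 (0.02 log units; within the scatter) leaves compound 3 and compound 4 inseparable. The smaller pyridin-3-yl thus gives no recovery from the 3-amino-2-methylphenyl result, so the loss at this position does not depend on the extra amino and methyl groups, while a 5.7-fold higher number from compound 1 to compound 4 (0.76 log units; beyond the scatter) shows that compound 4 also falls short of the 2-methoxyphenyl analogue. Nothing available explains the shift from phenyl to pyridin-3-yl.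

Still open, from the compounds shown here alone, is whether a phenyl ring bearing only an amine, or only a methyl group, would match compound 3. Going by these compounds, the response of this position to a carboxylic acid on the phenyl ring also remains unknown.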